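One methyl removed from the pyrazolyl group of compound 3

The source may report more compounds than this note shows. Statements on the series, on what has been measured and on what is new or still open speak of the compounds shown alone.

Compound 3 `Cc1cc(C)c(CN2CCc3c(Cl)cc(-c4c(C)n[nH]c4C)c(Cl)c3C2=O)c(=O)[nH]1` carries 3,5-dimethyl-1H-pyrazol-4-yl on an aromatic carbon of the shared core. In an assay on Sf9 cells for inhibition of histone-lysine N-methyltransferase EZH2 (Homo sapiens), read by scintillation counting, with a stated time of 60 min, in the presence of a further agent that is not named here (on this read-out lower numbers stand for stronger inhibition and higher numbers for weaker inhibition), compound 3 gives 16 nM, the lowest of the three numbers measured. Compound 1 `Cc1cc(C)c(CN2CCc3c(Cl)cc(-c4cn[nH]c4)c(Cl)c3C2=O)c(=O)[nH]1` gives 51 nM in this assay, and compound 2 `Cc1cc(C)c(CN2CCc3ccc(OC(C)C)cc3C2=O)c(=O)[nH]1` gives 8100 nM, far above both. For the measured compounds named here, the single recorded step, a 3.2-fold lower number from compound 1 to compound 3 (0.50 log units; beyond the scatter), shows that the dimethyl pyrazolyl group went with the lower number.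

Compound 4 `Cc1cc(C)c(CN2CCc3c(Cl)cc(-c4cn[nH]c4C)c(Cl)c3C2=O)c(=O)[nH]1` has not been measured. It differs from compound 3 by hydrogen in place of methyl on an aromatic carbon, in words hydrogen in place of methyl on an aromatic carbon, so that 3,5-dimethyl-1H-pyrazol-4-yl becomes 5-methyl-1H-pyrazol-4-yl. Compound 4 thus lies between compound 1 and compound 3 in structure, and the step from compound 1 to compound 3 is the only one that bears on it. Removing one of the two methyls is expected to give back part of that gain, a modest rise in this assay. The expected step is a 1.8-fold higher number from compound 3 to compound 4 (0.24 log units; within the scatter). Compound 4 is estimated at 28 nM, with a range from 10 nM to 80 nM.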

Compound 4, half-maximal inhibitory concentration in the histone-lysine N-methyltransferase EZH2 assay: 24 nM
Compound 4: middle estimate off by 1.2-fold (0.07 log units), on the high side, within the range that was stated.
By their numbers in the histone-lysine N-methyltransferase EZH2 assay, from the lowest: compounds 3 and 4 (each within the scatter of the next); then compound 1; then compound 2.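

In the histone-lysine N-methyltransferase EZH2 assay compound 4 gives 24 nM and so one methyl on the pyrazolyl group is enough for a step beyond the scatter (a 2.1-fold lower number from compound 1 to compound 4 (0.33 log units; beyond the scatter)), while taking away the second methyl gives only a step within it (a 1.5-fold higher number from compound 3 to compound 4 (0.18 log units; within the scatter)). On this read-out, therefore, 3,5-dimethyl-1H-pyrazol-4-yl and 5-methyl-1H-pyrazol-4-yl cannot be told apart, and the gain seen for the dimethyl group in the earlier step is already largely present with a single methyl. In a physicochemical assay for lipophilicity, at pH 7.4 (a higher number here means a more lipophilic compound, a lower number a more polar compound), compound 3 gives 3.4 and compound 4 gives 3.1 and the same change also stays within the scatter (a number 0.30 log units lower from compound 3 to compound 4 (within the scatter)).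

The compounds shown leave open how an ethyl, a methoxy or an amine would fare in place of this methyl. No evidence here explains why a single methyl goes with the lower number in the histone-lysine N-methyltransferase EZH2 assay.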